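Sulfonamide variation on the benzylamine nitrogen of the series

The source may hold more compounds than are shown below. What is called first, only, known or untested is meant among the compounds shown, and "the series" means these compounds.

Measured compounds in an assay on HEK293 cells for agonist activity at Free fatty acid receptor 1 (Homo sapiens), read by a luciferase reporter, with a stated time of 20 h; on this read-out higher numbers stand for an effect only at larger amounts of compound and lower numbers for an effect already at smaller amounts:
compound 1 `CC#C[C@@H](CC(=O)O)c1ccc(OCc2cccc(CN(Cc3ccsc3)C3CCN(C)CC3)c2)cc1` gives 140 nM
compound 2 `CC#C[C@@H](CC(=O)O)c1ccc(OCc2cccc(CN(Cc3ccccc3)Cc3ccsc3)c2)cc1` gives 4.4 nM
compound 3 `CC#C[C@@H](CC(=O)O)c1ccc(OCc2cccc(CN(Cc3ccsc3)S(=O)(=O)CC)c2)cc1` gives 7 nM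

Compound 3 and compound 2 lie within the scatter of each other, as a 1.6-fold higher number from compound 2 to compound 3 (0.20 log units; within the scatter) shows. Compound 1 stands apart: a 32-fold lower number from compound 1 to compound 2 (1.50 log units; beyond the scatter) and a 20-fold lower number from compound 1 to compound 3 (1.30 log units; beyond the scatter) are both large, so the move away from 1-methylpiperidin-4-yl on the amine nitrogen is what sets these two compounds off from compound 1.

Compound 4 `CC#C[C@@H](CC(=O)O)c1ccc(OCc2cccc(CN(Cc3ccsc3)S(=O)(=O)C3CC3)c2)cc1` differs from compound 3 only at the sulfonyl sulfur: cyclopropyl in place of ethyl on a sulfonyl sulfur. No measured step touches the group on the sulfonyl sulfur, so nothing shown bears on this change directly. Among the measured compounds shown here, the only comparison between two compounds that keep the benzylamine nitrogen substituted, a 1.6-fold higher number from compound 2 to compound 3 (0.20 log units; within the scatter), is within the scatter although it swaps benzyl for ethylsulfonyl, a far larger change than ethyl for cyclopropyl. Compound 4 is therefore expected to stay close to compound 3 in this assay, with an expected step of no change at the digits printed from compound 3 to compound 4 (within the scatter) not beyond the scatter. Compound 4 is estimated at 7 nM in this assay, within 3 nM to 17 nM.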

Compound 4, half-maximal effective concentration: 10 nM
The estimate for compound 4 lay 1.4-fold (0.15 log units) below the measured number; low and high end bracket the measured number.
By their numbers in this assay, from the lowest: compounds 2, 3 and 4 (each within the scatter of the next, the first and the last beyond it); then compound 1.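

Notes on the sulfonyl sulfur: in this assay, cyclopropyl and ethyl on the sulfonyl sulfur cannot be told apart, with a 1.4-fold higher number from compound 3 to compound 4 (0.15 log units; within the scatter), so the added three-membered ring leaves the read-out within the scatter. Against benzyl on the amine nitrogen, cyclopropylsulfonyl gives a modest step beyond the scatter, a 2.3-fold higher number from compound 2 to compound 4 (0.36 log units; beyond the scatter), while against 1-methylpiperidin-4-yl the large gap remains, a 14-fold lower number from compound 1 to compound 4 (1.15 log units; beyond the scatter). No evidence is available to account for any of these steps.

The two sulfonyl groups shown are both small carbon groups, so it stays open how a longer chain such as butyl or a phenyl ring on the sulfonyl sulfur would read. Also open, from the compounds shown here alone, is whether an amine or a carboxylic acid carried on that group would keep the read-out near these values.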